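Amide for acid on the other diastereomer

This account rests on a few compounds, and the source may have more. Where it says the series, first, only, none or still open, it means among the compounds named here.

Compound 3 `C=C1[C@H](CCCC)[C@H]1CC(=O)O` gives the highest number of the three measured, with 30000 nM in a functional assay (Hepatocyte) for inhibition, with Rattus norvegicus as the target; a higher number here means a weaker inhibitor, a lower number a stronger inhibitor. Compound 1 `C=C1[C@@H](CC(=O)O)[C@H]1CCCC` gives 15000 nM, and the step of a 2.0-fold higher number from compound 1 to compound 3 (0.30 log units; within the scatter) rests on (the fact that compounds 1 and 3 differ only in the configuration as drawn). Compound 2 `C=C1[C@@H](CC(N)=O)[C@H]1CCCC` gives 4000 nM, and the step of a 3.8-fold lower number from compound 1 to compound 2 (0.57 log units; beyond the scatter) carries the same change now applied to compound 3.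

Compound 4 `C=C1[C@H](CCCC)[C@H]1CC(N)=O` differs from compound 3 by amino in place of hydroxy on a carbonyl carbon. For the measured compounds named here, the one measured step that bears on this change, the step from compound 1 to compound 2, gave a modest lowering beyond the scatter, so the same direction and a similar size are expected here, while the step of a 2.0-fold higher number from compound 1 to compound 3 (0.30 log units; within the scatter) lies within the scatter and gives no reason to expect the second diastereomer to respond differently. The expected step is a 3.8-fold lower number from compound 3 to compound 4 (0.57 log units; beyond the scatter). For compound 4 the estimate in this assay is 8000 nM, with a range from 3000 nM to 20000 nM.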

Compound 4, half-maximal inhibitory concentration: 60000 nM
The estimate for compound 4 lay 7.5-fold (0.88 log units) below the measured number; the measured number lies above the stated range.
By their numbers in this assay, from the lowest: compound 2; then compounds 1, 3 and 4 (each within the scatter of the next, the first and the last beyond it).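

The change from carboxy to carbamoyl does not carry over between the two configurations in this assay: on this diastereomer it gives a 2.0-fold higher number from compound 3 to compound 4 (0.30 log units; within the scatter), with none of the clear lowering seen on the core of compound 1. The two readings of the same change disagree by more than the scatter of two such steps: the same change on two cores in this assay, a 3.8-fold lower number (0.57 log units; beyond the scatter) from compound 1 to compound 2 and a 2.0-fold higher number (0.30 log units; within the scatter) from compound 3 to compound 4, 7.5-fold (0.88 log units) apart, beyond the scatter of two such steps. Configuration, which gave no step beyond the scatter between the acids, counts among the amides, with a 15-fold higher number from compound 2 to compound 4 (1.18 log units; beyond the scatter): the fact that compounds 2 and 4 differ only in the configuration as drawn.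

The compounds shown leave open whether other groups on the carbonyl carbon, such as a methyl ester or a methylamide, would follow compound 2 or compound 4. They also leave open whether the same split between configurations holds with a longer chain on the shared core.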